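Cytotoxicity in HEL cells: from trimethoxyphenyl to halophenyl

This account rests on a few compounds, and the source may have more. Where it says the series, first, only, none or still open, it means among the compounds named here.

Compound 1 `CCOC(=O)C1(Cc2ccccc2)CN(c2ccccc2)Cc2nnn(Cc3ccccc3)c21` — in an ADME assay on HEL cells (Homo sapiens) for cytotoxicity, read by microscopy, with a stated time of 3 days (a higher number here means that more compound is tolerated, a lower number that less compound is tolerated), compound 1 gives >= 20000 nM, a limit of the assay.
Compound 2 `CCOC(=O)C1(Cc2ccccc2)CN(c2ccccc2)Cc2nnn(Cc3cc(OC)c(OC)c(OC)c3)c21` — in this assay compound 2 gives >= 100000 nM, a limit of the assay.

Compound 2 stands at the limit of >= 100000 nM in this assay, at which 1 of the 2 values shown sits, the higher of the two values shown. Compound 1 stands at the limit of >= 20000 nM in this assay, at which 1 of the 2 values shown sits. Going by the values given here, the only measured step, a step that the two limits leave unreadable from compound 1 to compound 2, is unreadable: both values are limits, so the size of the change from compound 1 to compound 2 on the trimethoxy substitution cannot be told.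

Compound 3 `CCOC(=O)C1(Cc2ccccc2)CN(c2ccccc2)Cc2nnn(Cc3c(F)cccc3Cl)c21` differs from compound 2 by 2-chloro-6-fluorophenyl in place of 3,4,5-trimethoxyphenyl on a saturated chain carbon bound to an aromatic nitrogen. Among the compounds with values here, no measured step bears on this exchange, and the one step available gives no readable size. The two measured compounds show only that neither reached a cytotoxic concentration within the tested range in this assay. Compound 3 is therefore expected to give 50000 nM, with a range from 15000 nM to 200000 nM, most probably again reported as a limit. The step of an at least 2.0-fold lower number from compound 2 to compound 3 (0.30 log units; that floor lies within the scatter) is estimated to lie within the scatter of this assay.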

Compound 3, minimum cytotoxic concentration: > 100000 nM
Compound 3: no number, only a limit; the forecaster's own chance of this, stated with the estimate: 80%; middle value at least 2.0-fold (0.30 log units) away from the limit.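

In this assay compound 3 gives > 100000 nM, a limit of the assay. The steps among compound 1, compound 2 and compound 3 all join limits, so none of them can be read. The compounds shown leave open at what concentration each becomes cytotoxic, and whether exchanging the group on the saturated chain carbon changes that concentration.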